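Replacing the side group of compound 3 with (oxolan-3-yl)oxy

This account rests on a few compounds, and the source may have more. Where it says the series, first, only, none or still open, it means among the compounds named here.

In an ADME assay on microsomes from liver (Mus musculus) for metabolic stability, read by LC-MS, using NADPH, with stated times of 10 min and 30 min, tested at 1 uM (on this read-out higher numbers stand for fast clearance and lower numbers for slow clearance), compound 1 `COC(=O)C1=C(CN2CCCCC2)NC(c2nccs2)=NC1(C)c1ccc(F)cc1` gives 88 mL/min/kg, compound 2 `COC(=O)C1=C(CN2CCC(F)(F)CC2)NC(c2nccs2)=NC1(C)c1ccc(F)cc1` gives 88 mL/min/kg, and compound 3 `COC(=O)C1=C(CN2CCCS2(=O)=O)NC(c2nccs2)=NC1(C)c1ccc(F)cc1` gives 79 mL/min/kg. Compound 3 therefore stands within the scatter of both other compounds. Compound 4 `COC(=O)C1=C(COC2CCOC2)NC(c2nccs2)=NC1(C)c1ccc(F)cc1` differs from compound 3 on a saturated chain carbon bound to a double-bonded ring carbon, where (oxolan-3-yl)oxy enters: a group of 6 heavy atoms (4 carbon, 2 oxygen; one five-membered non-aromatic ring with 1 hetero atom) in place of a group of 7 heavy atoms (3 carbon, 1 nitrogen, 2 oxygen, 1 sulfur; one five-membered non-aromatic ring with 2 hetero atoms), on a saturated chain carbon bound to a double-bonded ring carbon. Going by the values given here, three measured steps bear on this place, and all are small: no change at the digits printed from compound 1 to compound 2 (within the scatter), a 1.1-fold lower number from compound 1 to compound 3 (0.05 log units; within the scatter) and a 1.1-fold lower number from compound 2 to compound 3 (0.05 log units; within the scatter). Among the compounds with values here, none of the measured compounds carries (oxolan-3-yl)oxy, so this group itself remains untested in this assay. Since the three groups compared so far leave the clearance within the scatter, a step beyond the scatter is not expected in either direction. The expected step is a 1.1-fold lower number from compound 3 to compound 4 (0.02 log units; within the scatter). The estimate for compound 4 is 75 mL/min/kg, with an expected range from 48 mL/min/kg to 105 mL/min/kg.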

Compound 4, clearance: 79 mL/min/kg
Beside the measured number, compound 4's estimate is 1.1-fold (0.02 log units) below it; the measured number falls inside the stated range.
By their numbers in this assay, from the lowest: compounds 3, 4, 1 and 2 (each within the scatter of the next).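

In this assay, (oxolan-3-yl)oxy on a saturated chain carbon bound to a double-bonded ring carbon gives no change at the digits printed from compound 3 to compound 4 (within the scatter), along with a 1.1-fold lower number from compound 2 to compound 4 (0.05 log units; within the scatter) and a 1.1-fold lower number from compound 1 to compound 4 (0.05 log units; within the scatter). The three earlier groups all contain nitrogen and (oxolan-3-yl)oxy contains none, so across compounds 1 to 4 the clearance stays within the scatter even when this atom is absent from the group at this place. No available evidence accounts for how little these groups differ.

As far as these compounds go, it remains open whether a carboxylic acid or a longer chain at this place would give a step beyond the scatter. The compounds shown also leave open how the clearance responds to a change elsewhere on the shared core, such as a carboxylic acid in place of the methyl ester.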